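Notes on the aryl replacement from compound 3 to compound 4

The source may report more compounds than this note shows. Statements on the series, on what has been measured and on what is new or still open speak of the compounds shown alone.

Measured so far:
compound 1, `Nc1sc(-c2ccccc2)cc1C(=O)c1ccccc1`: 1%
compound 2, `CN(C)c1ccc(-c2cc(C(=O)c3ccccc3)c(N)s2)cc1`: 29%
compound 3, `Nc1sc(-c2cncnc2)cc1C(=O)c1ccccc1`: 2%

All three were read in an assay on CHO cells for positive allosteric modulation of adenosine receptor A1 (Homo sapiens), read by ERK phosphorylation, tested at 10 uM; a higher number here means a weaker effect of the compound at the concentration tested, a lower number a stronger effect. Compound 3 stands second highest of the three numbers. Its nearest neighbour is compound 1, the step being a number 1 percentage points higher from compound 1 to compound 3 (within the scatter). Compound 2 lies furthest away; the gap between compound 1 and compound 2 is a number 28 percentage points higher from compound 1 to compound 2 (beyond the scatter), and the values of compound 2 and compound 3 likewise differ by more than the scatter, whereas those of compound 1 and compound 3 do not.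

Compound 4, `Nc1sc(-c2ccncc2)cc1C(=O)c1ccccc1`, is not yet measured. It differs from compound 3 in one place: pyridin-4-yl in place of pyrimidin-5-yl on an aromatic carbon. Among the measured compounds shown here, the only measured step that bears on this change is the one from compound 1 to compound 3, a number 1 percentage points higher from compound 1 to compound 3 (within the scatter), where one six-membered ring was exchanged for another at the same place and the read-out did not move beyond the scatter. The step from compound 1 to compound 2 concerns a different group and gives little guidance here. Taking compound 4 as a further six-membered ring at this place, a step from compound 3 to compound 4 of no more than the scatter is expected, a number 1 percentage points higher from compound 3 to compound 4 (within the scatter). Compound 4 is therefore estimated at 3% in this assay, with a range from -5% to 12%.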

Compound 4, a percentage reported as activity, at one concentration (the size of the read-out at that concentration, not a potency): 17%
The estimate for compound 4 lay 14 percentage points below the measured number; the whole stated range lies below it.
By their numbers in this assay, from the lowest: compounds 1 and 3 (each within the scatter of the next); then compound 4; then compound 2.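

In this assay the aromatic carbon next to the ring sulfur turns out to be sensitive to which six-membered aromatic ring it carries, with a weaker effect for pyridin-4-yl than for pyrimidin-5-yl (a number 15 percentage points higher from compound 3 to compound 4 (beyond the scatter)) and than for phenyl (a number 16 percentage points higher from compound 1 to compound 4 (beyond the scatter)). The earlier exchange of phenyl for pyrimidin-5-yl gave values within the scatter of each other, so that step alone could have suggested that ring exchanges here leave the read-out unchanged; compound 4 goes against that reading. The number of ring nitrogens does not order the three compounds either, as the rings with none and with two sit together while the ring with one stands apart, and no measurement available accounts for this step.

Open, from the compounds shown here alone, is whether the step follows the place of the ring nitrogen, which pyridin-3-yl or pyridin-2-yl at this carbon would test directly. Also open, going by these compounds, is how a pyridin-4-yl ring carrying a further group, such as a methoxy group or an amine, would read in this assay.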